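From methoxy to cyclopropyl: the step to compound 4

The source may report more compounds than this note shows. Statements on the series, on what has been measured and on what is new or still open speak of the compounds shown alone.

Compound 3 `COc1nc(-c2cc(C)c(OCCCc3cc(C)no3)c(C)c2)no1` gives 0.55 h in an in vitro ADME assay on microsomes from liver (Simiiformes) (a higher number here means that the compound lasts longer, a lower number that the compound disappears faster), as its half-life. Compound 1 `CCc1cc(CCCOc2c(C)cc(-c3noc(C4CC4)n3)cc2C)on1` gives 0.9 h in this assay and lies within the scatter of compound 3, so the two cannot be told apart. Compound 2 `Cc1cc(-c2noc(C3CC3)n2)cc(C)c1OCCCc1cc(C2CC2)no1` stands at > 2.5 h and that figure is a limit of the assay, not a number.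

Compound 4 `Cc1cc(CCCOc2c(C)cc(-c3noc(C4CC4)n3)cc2C)on1` carries 5-cyclopropyl-1,2,4-oxadiazol-3-yl where compound 3 carries 5-methoxy-1,2,4-oxadiazol-3-yl, which puts cyclopropyl in place of methoxy on an aromatic carbon and gives it the group also found in compound 1 and compound 2. Among the compounds with values here, no measured step covers this exact change. Within the data shown here, the only measured step in which a cyclopropyl enters, replacing ethyl, is an at least 2.7-fold higher number from compound 1 to compound 2 (0.44 log units; beyond the scatter) and it lies beyond the scatter, but it sits at another place in the molecule and so bears only loosely on this one. Compound 1 with that same cyclopropyl group gives 0.9 h as the closer guide, so a small upward step in this assay is expected, one that may not clear the scatter. The expected step is a 1.8-fold higher number from compound 3 to compound 4 (0.26 log units; within the scatter) in this estimate. For compound 4 the estimated half-life is 1 h with an expected range from 0.45 h to 2.3 h in this assay at this stage.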

Compound 4, half-life: 2.23 h
For compound 4 the middle estimate is 2.2-fold (0.35 log units) below the measured one; the range from low to high includes it.
By their numbers in this assay, from the lowest: compounds 3 and 1 (each within the scatter of the next); then compound 4. At a limit, above all of these: compound 2.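

At the aromatic carbon next to the ring nitrogen and next to the ring oxygen, cyclopropyl in place of methoxy gives a 4.1-fold higher number from compound 3 to compound 4 (0.61 log units; beyond the scatter) in this assay, a modest step, so this change now has a direct measurement of its own and it lies beyond the scatter. The result also gives a second reading at the other place of change: with the 5-cyclopropyl-1,2,4-oxadiazol-3-yl group held constant, methyl in place of ethyl gives a 2.5-fold higher number from compound 1 to compound 4 (0.39 log units; beyond the scatter). Read beside an at least 2.7-fold higher number from compound 1 to compound 2 (0.44 log units; beyond the scatter), this leaves compound 1, with ethyl, below both compound 2 and compound 4, with cyclopropyl and methyl at that place.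

Compound 2 stands at > 2.5 h, a limit and not a number. As far as these compounds go, the step reads an at least 1.1-fold lower number from compound 2 to compound 4 (0.04 log units; that floor lies within the scatter), so it gives only a floor, and cyclopropyl and methyl at that place remain unordered: the limit of > 2.5 h in this assay, at which 1 of the 4 values shown sits. It remains open how an amine, a longer chain or trifluoromethyl would compare with cyclopropyl and methoxy on the oxadiazole carbon, and whether the step from methoxy to cyclopropyl keeps its size with ethyl or cyclopropyl at the second place of change.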